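This account rests on a few compounds, and the source may have more. Where it says the series, first, only, none or still open, it means among the compounds named here.

Of the compounds shown here, three have been measured in an assay on Sf9 cells for inhibition of protein deacetylase HDAC6 (Homo sapiens), read by fluorescence, with a stated time of 90 min; a lower number here means a stronger inhibitor, a higher number a weaker inhibitor. Compound 1 `Cc1ccc(C(=O)N(CC(=O)NCc2ccccc2)Cc2ccc(C(=O)NO)cc2)c(C)c1` gives 60 nM. Compound 3 `Cc1ccc(C(=O)N(CC(=O)NC2CCCCC2)Cc2ccc(C(=O)NO)cc2)c(C)c1` gives 40 nM, and the change a 1.5-fold lower number from compound 1 to compound 3 (0.18 log units; within the scatter) shows how little that swap of the amide substituent mattered. Compound 2 `CC(C)c1ccc(C(=O)N(Cc2ccc(C(=O)NO)cc2)C(C)(C)C(=O)NC2CCCCC2)cc1` gives 270 nM; it differs from compound 1 in several places at once, so no single step can be read from it, but its number lies beyond the usual scatter from that of compound 1. Compound 1 thus stands second highest of the three numbers, with compound 3 close by and compound 2 further off.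

Compound 4 `O=C(CN(Cc1ccc(C(=O)NO)cc1)C(=O)c1cccc2ccccc12)NCc1ccccc1` is not yet measured. It differs from compound 1 in one place: naphthalen-1-yl in place of 2,4-dimethylphenyl on a carbonyl carbon. For the measured compounds named here, none of the measured steps touches this part of the molecule, so there is no direct guide to the size or direction of the change. On that basis the step is expected to be small, a 1.2-fold higher number from compound 1 to compound 4 (0.07 log units; within the scatter). Compound 4 is therefore estimated to give 70 nM in this assay, with a likely range from 25 nM to 200 nM.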

Compound 4, half-maximal inhibitory concentration: 10 nM
Compound 4: the middle estimate sits 7.0-fold (0.85 log units) above what was measured; the measured number lies below the stated range.
By their numbers in this assay, from the lowest: compound 4; then compounds 3 and 1 (each within the scatter of the next); then compound 2.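

In this assay, the group on the carbonyl carbon turns out to matter: naphthalen-1-yl in place of 2,4-dimethylphenyl gives a 6.0-fold lower number from compound 1 to compound 4 (0.78 log units; beyond the scatter) for a change of a single group. For the compounds shown here, the only earlier one-place step, at the amide substituent, gave a 1.5-fold lower number from compound 1 to compound 3 (0.18 log units; within the scatter), so this is the first place where a single swap clearly moves the number. The change is an all-carbon one, with a second six-membered aromatic ring entering, the two methyl groups leaving, and no hydrogen-bond donors, acceptors or charge on either group.

Nothing at hand explains why the number falls. On these data alone, it also remains open how a plain phenyl or a naphthalen-2-yl group would behave on this carbonyl, and whether the gain carries over to the cyclohexyl amide of compound 3.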